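Chloro for Hydrogen on the Core: Tolerance in Vero Cells

The source may report more compounds than this note shows. Statements on the series, on what has been measured and on what is new or still open speak of the compounds shown alone.

Compound 1 `OC[C@H]1O[C@@H](n2cnc3c(NC(C4CCC4)C4CCC4)ncnc32)[C@H](O)[C@@H]1O` — in an ADME assay on Vero 76 cells (Chlorocebus sabaeus) for cytotoxicity, read by microscopy (a higher number here means that more compound is tolerated, a lower number that less compound is tolerated), compound 1 gives > 100000 nM, which is a limit of the assay and not a number.
Compound 2 `O[C@@H]1[C@H](O)[C@@H]2C[C@@H]2[C@H]1n1ccc2c(NC(C3CC3)C3CC3)nc(I)nc21` — in this assay compound 2 gives 100000 nM.
Compound 3 `NCCNC(=O)[C@@]12C[C@@H]1[C@@H](n1cnc3c(NC(C4CC4)C4CC4)nc(Cl)nc31)[C@H](O)[C@@H]2O` — in this assay compound 3 gives > 50000 nM, again a limit rather than a number.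

Compound 1 thus stands only at a limit in this assay, and one further value among the three is also a limit: one sits at the limit of > 100000 nM in this assay, at which 1 of the 3 values shown sits, and one at the limit of > 50000 nM in this assay, at which 1 of the 3 values shown sits. Going by the values given here, no step between two measured compounds that differ in a single place is available here, so the size of any change cannot be read from the data.

Compound 4 `OC[C@H]1O[C@@H](n2cnc3c(NC(C4CCC4)C4CCC4)nc(Cl)nc32)[C@H](O)[C@@H]1O` differs from compound 1 by chloro in place of hydrogen on an aromatic carbon. Across the three measured compounds no value falls clearly into the toxic range, so the step is expected to be none beyond the scatter: a number no higher from compound 1 to compound 4 (the limit leaves the size open). Compound 4 is therefore expected to give about 100000 nM, within 30000 nM to 300000 nM, quite possibly reported only as a limit.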

Compound 4, half-maximal cytotoxic concentration: 32000 nM
The estimate for compound 4 lay 3.1-fold (0.49 log units) above the measured number, and the stated range covers the measured number.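

Chloro in place of hydrogen on an aromatic carbon, between two ring nitrogen atoms, is the first change in this set that can be read as a step in this assay, and it gives an at least 3.1-fold lower number from compound 1 to compound 4 (0.49 log units; beyond the scatter). This shows that the position is not indifferent to the change, as less compound is tolerated with chloro there than with hydrogen on the otherwise unchanged structure. The full size of the step remains open, as compound 1 stands at a limit and not at a number: the limit of > 100000 nM in this assay, at which 1 of the 4 values shown sits.

From the compounds shown here alone, whether an amine, a methyl or a bromo group at this same carbon would lower the number as chloro does remains open. Also open, going by these compounds, is whether chloro in place of hydrogen has the same effect on a different core or with other groups on the ring nitrogen-bearing side of the structure.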